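Carbonyl substituent variation on the shared core

This account rests on a few compounds, and the source may have more. Where it says the series, first, only, none or still open, it means among the compounds named here.

compound 1 `CC1=C(C(=O)OC(C)(C)C)C(c2cccs2)NC(=O)N1`: 26%
compound 2 `CC1=C(C(=O)CC(C)C)C(c2ccco2)NC(=O)N1`: 16%
compound 3 `CC1=C(C(=O)C2CC2)C(c2cccs2)NC(=O)N1`: 1%

In an assay on membranes from CHO cells for displacement of a labelled ligand from adenosine receptor A1 (Homo sapiens), read by scintillation counting, with a stated time of 60 min, tested at 1 uM (on this read-out higher numbers stand for more inhibition at the one concentration tested (going by the name of the read-out) and lower numbers for less inhibition), compound 3 gives 1%, the lowest of the three numbers. Compound 2 gives 16%, a number that lies beyond the scatter higher than that of compound 3. Compound 1 gives 26%, the furthest of the three from compound 3 and likewise beyond the scatter. Compound 4 `CC1=C(C(=O)CC(C)C)C(c2cccs2)NC(=O)N1` differs from compound 3 by isobutyl in place of cyclopropyl on a carbonyl carbon. Within the data shown here, the only measured step, a number 25 percentage points lower from compound 1 to compound 3 (beyond the scatter), concerns a different group replaced at the carbonyl carbon and does not bear directly on this change. Compound 2 shares the isobutylcarbonyl of compound 4 and differs from it elsewhere on the core, so its value is the nearest guide. An upward step in this assay beyond the scatter is therefore expected, though with wide uncertainty. The expected step is a number 13 percentage points higher from compound 3 to compound 4 (beyond the scatter). Compound 4 is estimated at 14%, with a range from 0% to 32%.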

Compound 4, a percentage reported as inhibition, at one concentration (the size of the read-out at that concentration, not a potency): 19%
For compound 4 the middle estimate is 5 percentage points below the measured one, within the range that was stated.
By their numbers in this assay, from the lowest: compound 3; then compounds 2, 4 and 1 (each within the scatter of the next).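

On the carbonyl carbon, the change from cyclopropyl to isobutyl now has a direct reading (a number 18 percentage points higher from compound 3 to compound 4 (beyond the scatter)). With thiophen-2-yl held, isobutyl and tert-butoxy on the carbonyl carbon cannot be told apart (a number 7 percentage points lower from compound 1 to compound 4 (within the scatter)), and with isobutylcarbonyl held, neither can thiophen-2-yl and furan-2-yl on a saturated ring carbon (a number 3 percentage points higher from compound 2 to compound 4 (within the scatter)), so among these groups only the cyclopropyl of compound 3 stands apart. Nothing available explains this difference.

Open, going by these compounds, is whether a longer chain or an amine on this carbonyl carbon would give a number beyond that of compound 4. Also open, on these data alone, is whether the cyclopropyl result holds with furan-2-yl on the saturated ring carbon.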